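Working notes: from compound 3 to compound 4

The compounds below may be only part of what the source reports. "The series", "measured", "known", "first", "only" and "open" are said of these compounds alone.

Measured so far in a functional assay on HepG2 cells (Homo sapiens) for inhibition, read by MTT assay, with a stated time of 72 h; on this read-out lower numbers stand for stronger inhibition and higher numbers for weaker inhibition:
- compound 1 `CCCc1ccc(NC(=O)C2CCN(C/C=C/c3ccccc3)CC2)cc1` gives 9410 nM
- compound 2 `O=C(Nc1cccc(F)c1)C1CCN(C/C=C/c2ccccc2)CC1` gives 51100 nM
- compound 3 `O=C(Nc1cccc(Cl)c1)C1CCN(C/C=C/c2ccccc2)CC1` gives 20000 nM

Compound 3 holds the middle number of the three in this assay and sits closer to compound 1 than to compound 2, with a 2.1-fold higher number from compound 1 to compound 3 (0.33 log units; beyond the scatter) and a 2.6-fold lower number from compound 2 to compound 3 (0.41 log units; beyond the scatter) as the two gaps. The next compound, still unmeasured, is compound 4 `O=C(Nc1ccc(F)c(Br)c1)C1CCN(C/C=C/c2ccccc2)CC1` and the change is 3-bromo-4-fluorophenyl in place of 3-chlorophenyl on an amide-type nitrogen with the rest of the structure kept. For the measured compounds named here, no measured compound carries bromo or two halogens, so no step covers this change directly.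

The closest evidence is a halogen exchange on the same ring, a 2.6-fold lower number from compound 2 to compound 3 (0.41 log units; beyond the scatter) for chloro in place of fluoro. The step of a 5.4-fold higher number from compound 1 to compound 2 (0.73 log units; beyond the scatter) shows that a larger change of the aryl group also stayed modest. A small move towards a lower number is therefore expected, most likely within the scatter, and a larger step in either direction cannot be excluded. The expected step is a 1.4-fold lower number from compound 3 to compound 4 (0.15 log units; within the scatter) on this reading. For compound 4 the estimated value is 14000 nM with an expected range from 5000 nM to 40000 nM in these notes.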

Compound 4, half-maximal inhibitory concentration: 8190 nM
Compound 4: middle estimate off by 1.7-fold (0.23 log units), on the high side; the range from low to high includes it.
By their numbers in this assay, from the lowest: compounds 4 and 1 (each within the scatter of the next); then compound 3; then compound 2.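

In this assay the aryl group on the amide-type nitrogen still responds to halogen changes when a second halogen is present: 3-bromo-4-fluorophenyl in place of 3-chlorophenyl gives a 2.4-fold lower number from compound 3 to compound 4 (0.39 log units; beyond the scatter) and in place of 3-fluorophenyl gives a 6.2-fold lower number from compound 2 to compound 4 (0.80 log units; beyond the scatter) as the wider gap, so the halogen-bearing aryl groups now span more than compounds 2 and 3 showed alone. Against 4-propylphenyl the change gives a 1.1-fold lower number from compound 1 to compound 4 (0.06 log units; within the scatter) and so separates nothing, which means an aryl group carrying two halogens and one carrying a propyl chain cannot be told apart on this read-out. No independent measurement is available that would explain these steps.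

The compounds shown leave open whether the bromo or the fluoro of the 3-bromo-4-fluorophenyl group carries the step, since the two enter together. Also open, going by these compounds, is how the same aryl group responds to an amine, a carboxylic acid or a chain longer than propyl, and whether any such group moves the number beyond that of compound 4.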